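Propoxy in place of hydrogen on the shared core

This account rests on a few compounds, and the source may have more. Where it says the series, first, only, none or still open, it means among the compounds named here.

Compound 1 `CCCCCCCC/C=C\CCCCCCCC(=O)OC[C@@H](C)OP(=O)(O)OC[C@H](N)C(=O)O` was tested in an assay on HEK293 cells for agonist activity at putative P2Y purinoceptor 10 (Mus musculus), with a stated time of 1 h (a higher number here means a larger maximal response, a lower number a smaller maximal response), and there compound 1 gives 12.4%. Among the two compounds measured, compound 1 stands highest, with compound 2 `CCCCCCCC/C=C\CCCCCCCC(=O)OC[C@H](C)OP(=O)(O)OC[C@H](N)C(=O)O` nearest; in this assay compound 2 gives 11.3%. Among the measured compounds shown here, the only measured step, a number 1.1 percentage points lower from compound 1 to compound 2 (within the scatter), lies within the scatter, so the two values show no difference, and the stereochemical nature of that pair is noted in the fact that one of compounds 1 and 2 is drawn with a defined configuration and the other without, at the place where they differ.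

Compound 3 `CCCCCCCC/C=C\CCCCCCCC(=O)OC[C@@H](COCCC)OP(=O)(O)OC[C@H](N)C(=O)O` has not yet been measured. It differs from compound 1 by propoxy in place of hydrogen on a saturated chain carbon, two bonds along the chain from an oxygen on an unsaturated carbon. For the measured compounds named here, no measured step touches a change of this kind: the one step in hand concerns a configuration, not an added group, and it stayed within the scatter. The data therefore give no ground to expect a step beyond the scatter for compound 3, and the expected step of a number 1.6 percentage points higher from compound 1 to compound 3 (within the scatter) is written as small. Compound 3 is estimated to reach 14% in this assay, with a range from 4% to 32% that allows for the unknown effect of the new group.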

Compound 3, largest response reached (Emax), in percent of the reference or control that the assay uses: "not active" (no number reported)
The entry for compound 3 holds no number, and the estimate cannot be compared.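

In this assay, among the compounds shown here, compound 3 is recorded as "not active" with no number, so no step from compound 1 to compound 3 can be read. Nothing in the available evidence bears on this result. The compounds shown leave open how large a change in maximal response propoxy in place of hydrogen brings, and in which direction.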